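The source may hold more compounds than are shown below. What is called first, only, known or untested is meant among the compounds shown, and "the series" means these compounds.

Compound 2 `CCn1c(C(=O)NCCN(C)C)ccc1C(CC)(CC)c1ccc(OCC(O)C(C)(C)C)c(C)c1` sits at the lowest of the two numbers that the series gives in a functional assay on Caco-2 cells (Homo sapiens), read by MTT assay, with a stated time of 48 h; a higher number here means a weaker inhibitor, a lower number a stronger inhibitor; in that assay compound 2 gives 1300 nM. Its nearest neighbour is compound 1 `CCn1c(C(=O)NCCN)ccc1C(CC)(CC)c1ccc(OCC(=O)C(C)(C)C)c(C)c1`, which in this assay gives 1900 nM, a gap that lies within the scatter. Compound 3 `C#CC(C)OC(=O)c1ccc(C(CC)(CC)c2ccc(OCC(O)C(C)(C)C)c(C)c2)n1CC` reaches only the limit of this assay, > 50000 nM, so no number is known for it. Among the measured compounds shown here, the one measured step that bears on the question is the exchange on the carbonyl carbon: an at least 38-fold higher number from compound 2 to compound 3 (1.58 log units; beyond the scatter), with the value landing at the limit (the limit of > 50000 nM in this assay, at which 1 of the 3 values shown sits).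

Compound 4 `CCn1c(C(=O)Oc2ccc(CCO)cc2)ccc1C(CC)(CC)c1ccc(OCC(O)C(C)(C)C)c(C)c1` is not yet measured. It differs from compound 2 by a group of 10 heavy atoms (8 carbon, 2 oxygen; one six-membered aromatic ring of carbon only) in place of a group of 6 heavy atoms (4 carbon, 2 nitrogen; no ring), on a carbonyl carbon. Here again the (2-(dimethylamino)ethyl)amino group leaves the carbonyl carbon, and a group built of carbon and oxygen, carrying one six-membered aromatic ring of carbon only, enters in its place. For the measured compounds named here, because an at least 38-fold higher number from compound 2 to compound 3 (1.58 log units; beyond the scatter) followed the only comparable exchange, a step in the same direction is expected for compound 4, a 23-fold higher number from compound 2 to compound 4 (1.36 log units; beyond the scatter). Compound 4 is therefore estimated in this assay at 30000 nM, with a range from 8000 nM to 60000 nM, and a real chance that only the limit is reported once more.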

Compound 4, half-maximal inhibitory concentration: > 50000 nM
Compound 4: no number, only a limit; the forecaster's own chance of this, stated with the estimate: 50%; middle value at least 1.6-fold (0.22 log units) from the limit.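

In this assay, the exchange on the carbonyl carbon now has a second example, and it runs the same way as the first: an at least 38-fold higher number from compound 2 to compound 4 (1.58 log units; beyond the scatter). Compound 4 gives > 50000 nM, which is a limit and not a number. The loss is therefore not tied to the 1-methylprop-2-yn-1-yl group, since a 4-(2-hydroxyethyl)phenyl group on that oxygen, with its six-membered aromatic ring, also ends at the limit, and the step between compound 3 and compound 4 cannot be read: the limit of > 50000 nM in this assay, at which 2 of the 4 values shown sit.

The compounds shown leave open what in the (2-(dimethylamino)ethyl)amino group carries the lower number in compound 2, since both exchanges remove the amide nitrogen and the dimethylamino group together. A 2-(dimethylamino)ethyl group on the oxygen of the carbonyl, or a 2-hydroxyethylamino group on the carbonyl carbon, would separate the two, and a longer chain such as 3-(dimethylamino)propylamino would show whether the length of that chain counts as well.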